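Desilylation of the alkyne sulfonamide: compound 2 to compound 3

The compounds below may be only part of what the source reports. "The series", "measured", "known", "first", "only" and "open" are said of these compounds alone.

Measured so far:
compound 1, `C#Cc1ccc(S(=O)(=O)Nc2cccc(-c3csc(NC(C)=O)n3)c2)cc1`: 38.3%
compound 2, `CC(=O)Nc1nc(-c2cccc(NS(=O)(=O)c3cccc(C#C[Si](C)(C)C)c3)c2)cs1`: < 1%

In a functional assay on A-375 cells (Homo sapiens) for antiproliferative activity, read by trypan blue exclusion, with a stated time of 48 h, tested at 5 uM (a lower number here means a stronger effect, a higher number a weaker effect of the compound at the concentration tested), compound 1 gives 38.3%. Compound 2 is reported in this assay only as a limit, < 1%, and not as a number. That limit is the limit of < 1% in this assay, at which 1 of the 2 values shown sits, so compound 2 stands at the strong end of what this assay reports, with no number behind it.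

Compound 3, `C#Cc1cccc(S(=O)(=O)Nc2cccc(-c3csc(NC(C)=O)n3)c2)c1`, is not yet measured. Compared with compound 2 the change is a hydrogen atom in place of a group of 4 heavy atoms (3 carbon, 1 silicon; no ring), on a triple-bonded carbon. Within the data shown here, no step between measured compounds is available here. Compound 1, which also carries a free terminal alkyne, gives 38.3% in this assay. Against that background the step from compound 2 to compound 3 is expected to be a loss beyond the usual scatter, estimated as a number at least 19 percentage points higher from compound 2 to compound 3 (beyond the scatter). Compound 3 is accordingly expected to give 20% in this assay, with an estimated range from 2% to 45%.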

Compound 3, a percentage reported as activity, at one concentration (the size of the read-out at that concentration, not a potency): 29%
Compound 3: the middle estimate sits 9 percentage points below what was measured; measured number inside the range.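

At the triple-bonded carbon of the 3-ethynylphenyl series, a hydrogen atom in place of the group of 4 heavy atoms (3 carbon, 1 silicon) weakens the effect in this assay, giving a number at least 28 percentage points higher from compound 2 to compound 3 (beyond the scatter). This step has only a lower bound, as the value of compound 2 is a limit and not a number: the limit of < 1% in this assay, at which 1 of the 3 values shown sits.
With 3-ethynylphenyl in place of 4-ethynylphenyl on a sulfonyl sulfur, the read-out gives a number 9.3 percentage points lower from compound 1 to compound 3 (within the scatter), so this assay does not separate these two free alkynes.

Open, going by these compounds, is whether the silicon atom itself matters, which a tert-butyl group on the same triple-bonded carbon would test. Also open, on these data alone, is whether the same group of 4 heavy atoms gives a comparable result on the 4-ethynylphenyl compound.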